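Furan ring size step in the nucleoside series

This account rests on a few compounds, and the source may have more. Where it says the series, first, only, none or still open, it means among the compounds named here.

Of the compounds shown here, three have been tested in a functional assay on CCRF-CEM cells (Homo sapiens), read by MTT assay, with a stated time of 72 h; a higher number here means a weaker inhibitor, a lower number a stronger inhibitor. Compound 1 `COc1nc(N)nc2c1c(-c1ccco1)cn2[C@@H]1O[C@H](CO)[C@@H](O)[C@H]1O` reaches only a limit of this assay at > 20000 nM. Compound 2 `Nc1nc(N)c2c(-c3ccoc3)cn([C@@H]3O[C@H](CO)[C@@H](O)[C@H]3O)c2n1` likewise reaches only a limit, > 20000 nM. Compound 3 `Nc1nc(N)c2c(-c3cc4ccccc4o3)cn([C@@H]3O[C@H](CO)[C@@H](O)[C@H]3O)c2n1` again sits at a limit, > 20000 nM. Among the measured compounds shown here, the single one-site step that has been measured, a step that the two limits leave unreadable from compound 2 to compound 3, cannot be read because of the limit of > 20000 nM in this assay, at which 3 of the 3 values shown sit. Compound 3 therefore stands at the same limit as the other two shown values, with no number to place it against.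

Compound 4 `Nc1nc(N)c2c(-c3ccco3)cn([C@@H]3O[C@H](CO)[C@@H](O)[C@H]3O)c2n1` differs from compound 3 by furan-2-yl in place of 1-benzofuran-2-yl on an aromatic carbon. For the measured compounds named here, the one measured step touches the same position but has no readable size, so neither direction nor magnitude can be taken from it. With every shown value a limit, the expected step in this assay is a number no higher from compound 3 to compound 4 (the limit leaves the size open), meaning no change that the data can resolve. Compound 4 is thus expected at 20000 nM, with a range of 8000 nM to 60000 nM, and most likely again reported as a limit rather than a number.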

Compound 4, half-maximal inhibitory concentration: > 20000 nM
Compound 4 ended at the assay's limit; the forecaster's own chance of this, stated with the estimate: 85%; the middle value lies on the limit itself.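

No new step can be read from compound 4 to compound 1, compound 2 or compound 3 in this assay, because each comparison ends at a limit: the limit of > 20000 nM in this assay, at which 4 of the 4 values shown sit.

The compounds shown leave open whether furan-2-yl, furan-3-yl, 1-benzofuran-2-yl, or amino against methoxy, changes the read-out at all.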